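The source may report more compounds than this note shows. Statements on the series, on what has been measured and on what is new or still open speak of the compounds shown alone.

Measured so far:
compound 1 `COc1ccc(NC(=O)Nc2nc(Sc3c[nH]c4ccccc34)cc(N3CCCCC3)n2)cc1`, 13500 nM
compound 2 `Cc1ccc(C)c(NC(=O)Nc2nc(Sc3c[nH]c4ccccc34)cc(N3CCCCC3)n2)c1`, 25400 nM
compound 3 `O=C(Nc1ccc(Cl)cc1)Nc1nc(Sc2c[nH]c3ccccc23)cc(N2CCCC2)n1`, 6410 nM

In a functional assay on A549 cells (Homo sapiens) for inhibition, with a stated time of 72 h (a higher number here means a weaker inhibitor, a lower number a stronger inhibitor), compound 1 gives 13500 nM, the second highest of the three numbers. Compound 2, which carries a different aryl group on the urea nitrogen, shows a 1.9-fold higher number from compound 1 to compound 2 (0.27 log units; within the scatter), so the two stand together within the scatter. Compound 3 differs from compound 1 in two places at once, a chlorophenyl on the urea and a pyrrolidinyl on the core; in this assay compound 3 gives 6410 nM, the lowest of the three.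

Compound 4 `COc1ccc(NC(=O)Nc2nc(Nc3cc(OC)cc(OC)c3)cc(Sc3c[nH]c4ccccc34)n2)cc1` is not yet measured. It changes compound 1 elsewhere: (3,5-dimethoxyphenyl)amino in place of piperidin-1-yl on an aromatic carbon. For the measured compounds named here, none of the measured steps touches this position with a single change, so no measured step bears directly on it; the only step available, from compound 1 to compound 2, concerns the urea aryl group and is within the scatter. For compound 4 the expectation in this assay is therefore a step of a 1.1-fold lower number from compound 1 to compound 4 (0.05 log units; within the scatter), that is, no change beyond the scatter, with a wide range. The estimate for compound 4 is 12000 nM, between 3000 nM and 45000 nM.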

Compound 4, half-maximal inhibitory concentration: > 50000 nM
Compound 4: only a limit was reported; the forecaster's own chance of this, stated with the estimate: 10%; middle value at least 4.1-fold (0.61 log units) away from the limit.
By their numbers in this assay, from the lowest: compound 3; then compounds 1 and 2 (each within the scatter of the next). At a limit, above all of these: compound 4.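

For the compounds shown here, this is the first single change at this place on the shared core, the aromatic carbon next to the ring nitrogen. In this assay, going by these compounds alone, (3,5-dimethoxyphenyl)amino in place of piperidin-1-yl gives an at least 3.7-fold higher number from compound 1 to compound 4 (0.56 log units; beyond the scatter), whereas the one earlier single step, on the urea aryl group, stayed within the scatter as a 1.9-fold higher number from compound 1 to compound 2 (0.27 log units; within the scatter). The value for compound 4 is a limit and not a number: the limit of > 50000 nM in this assay, at which 1 of the 4 values shown sits.

This one swap changes the ring type, the size of the group and the hydrogen-bond counts together, so the step cannot be assigned to any one of these. On these data alone, how a plain phenylamino group or a morpholin-4-yl group would behave at this place remains open, as does whether the two methoxy groups matter.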